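Replacing 4-fluorobenzyl with ethyl: cytotoxicity notes

A few compounds are considered here, and "the series" means these few. Any claim that something is new, unique, unknown or untested is made for them only; others in the source may bear on it.

Measured in an ADME assay on KB cells (Homo sapiens) for cytotoxicity; a higher number here means that more compound is needed for the effect, a lower number that less compound is needed:
- compound 1 `CCOC(=O)N1[C@@H]2C=C[C@@](OC)(C(=O)c3c2cc(OC)c(OC)c3OCc2ccc(F)cc2)N1C(=O)OCC` gives 51.8 ug/mL
- compound 2 `COC(=O)N1[C@@H]2C=C[C@@](OC)(C(=O)c3c2cc(OC)c(OC)c3OCc2ccccc2)N1C(=O)OC` gives > 300 ug/mL, a limit of the assay

Going by the values given here, compound 1 holds the only actual number in this assay so far. Compound 2 reports only the limit > 300 ug/mL.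

Compound 3 `CCOC(=O)N1[C@@H]2C=C[C@@](OC)(C(=O)c3c2cc(OC)c(OC)c3OCC)N1C(=O)OCC` has methyl in place of 4-fluorophenyl on a saturated chain carbon bound to an oxygen on an aromatic ring. Among the compounds with values here, no measured pair isolates this change. Within the data shown here, a higher number than that of compound 1 is still expected, since compound 2, the only other measured compound, gives > 300 ug/mL. The estimated change is a 2.3-fold higher number from compound 1 to compound 3 (0.36 log units; beyond the scatter), a moderate step toward needing more compound. For compound 3 the expected value is 120 ug/mL, with an estimated range of 40 ug/mL to 300 ug/mL.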

Compound 3, concentration for half-maximal effect: > 300 ug/mL
Compound 3 ended at the assay's limit (the forecaster's own chance of this, stated with the estimate: 25%); middle value at least 2.5-fold (0.39 log units) from the limit.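

In this assay, going by these compounds alone, exchanging 4-fluorobenzyl for ethyl gives an at least 5.7-fold higher number from compound 1 to compound 3 (0.76 log units; beyond the scatter), the first step that can be read at this position, a saturated chain carbon bound to an oxygen on an aromatic ring. Compound 3 gives > 300 ug/mL, which is a limit of the assay. Only the minimum size of the step can be read because compound 3 sits at that limit: the limit of > 300 ug/mL in this assay, at which 2 of the 3 values shown sit.

Compound 2 carries benzyl but differs from compound 1 in more than one place, so it does not show whether the step depends on the fluorine or on the whole aromatic ring. Also open, going by these compounds, is how a longer chain such as butyl, or a chain ending in an amine, would compare with 4-fluorobenzyl and ethyl on the shared core.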